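The source may hold more compounds than are shown below. What is called first, only, known or untested is meant among the compounds shown, and "the series" means these compounds.

In an ADME assay on S9 fraction from liver (Rattus norvegicus) for metabolic stability, read by LC-MS, using NADPH, with a stated time of 30 min (a higher number here means that more of the compound is left, a lower number that less of the compound is left), compound 1 `CCCCCCCCc1ccc(OCC(=O)Cn2ncnn2)cc1` gives < 5%. That figure is a limit of the assay and not a number, so compound 1 stands only at a bound, the one described by the limit of < 5% in this assay, at which 1 of the 3 values shown sits. Compound 2 `CCCCCCCCc1ccc(OCC(=O)Cn2nnc(-c3ccc(Cl)cc3)n2)cc1` gives 74% in this assay, and compound 3 `CCCCCCCCc1ccc(OCC(=O)Cn2nnc(-c3cccc(Cl)c3)n2)cc1` gives 69%. The two measured steps from the parent are both large: a number at least 69 percentage points higher from compound 1 to compound 2 (beyond the scatter) and a number at least 64 percentage points higher from compound 1 to compound 3 (beyond the scatter). Between the two aryl compounds there is a number 5 percentage points lower from compound 2 to compound 3 (within the scatter), so the two chlorophenyl positions cannot be told apart here.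

Compound 4 `CCCCCCCCc1ccc(OCC(=O)Cn2nnc(-c3ccccn3)n2)cc1` differs from compound 1 by pyridin-2-yl in place of hydrogen on an aromatic carbon. For the measured compounds named here, the steps that bear on it are the two aryl additions, each of them large and in the direction of more compound remaining. An aromatic six-membered ring again enters at the same place, so a large rise in this assay is expected, though the pyridin-2-yl ring has not itself been measured and the size is uncertain. Compound 4 is therefore expected to give about 55%, within a range of 20% to 85%. That estimate means an expected step of a number at least 50 percentage points higher from compound 1 to compound 4 (beyond the scatter).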

Compound 4, percent of the compound remaining: 30%
Beside the measured number, compound 4's estimate is 25 percentage points above it, within the range that was stated.
By their numbers in this assay, from the lowest: compound 4; then compounds 3 and 2 (each within the scatter of the next). At a limit, below all of these: compound 1.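

In this assay, a rise at this aromatic carbon of the five-membered aromatic ring with 4 nitrogen is not confined to the two chlorophenyl groups, as pyridin-2-yl gives a number at least 25 percentage points higher from compound 1 to compound 4 (beyond the scatter). The choice of ring also counts here, with a number 39 percentage points lower from compound 3 to compound 4 (beyond the scatter) and a number 44 percentage points lower from compound 2 to compound 4 (beyond the scatter), whereas the two chlorophenyl compounds could not be told apart. The first of these steps is a bound only, with compound 1 at a limit: the limit of < 5% in this assay, at which 1 of the 4 values shown sits.

Pyridin-2-yl differs from the chlorophenyl groups in both the ring nitrogen and the chlorine, so the compounds shown do not separate these two changes, and a plain phenyl ring would be needed to do so. Also open, from the compounds shown here alone, is whether a small group such as methyl at this carbon would give any rise, or whether pyridin-3-yl would match pyridin-2-yl.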